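Does a Larger Ring on the Nitrogen Change Cytotoxicity?

The compounds below may be only part of what the source reports. "The series", "measured", "known", "first", "only" and "open" are said of these compounds alone.

Compound 1 `CC(C)Nc1nc(N)nc2c1ncn2/C=C1/CC1(CO)CO` and compound 2 `Nc1nc(NC2CC2)c2ncn(/C=C3/CC3(CO)CO)c2n1` share a core and differ only in the group on a nitrogen on an aromatic ring. In an ADME assay on CCRF-HSB-2 cells (Homo sapiens) for cytotoxicity, with a stated time of 7 days (on this read-out lower numbers stand for higher toxicity in this test and higher numbers for lower toxicity in this test), compound 1 gives > 20000 nM, which is a limit of the assay and not a number. In this assay compound 2 gives > 20000 nM, which is also a limit. Compound 2 therefore stands on (the limit of > 20000 nM in this assay, at which 2 of the 2 values shown sit), with no exact value of its own.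

Compound 3 `Nc1nc(NC2CCCC2)c2ncn(/C=C3/CC3(CO)CO)c2n1` alters the same group: cyclopentyl in place of cyclopropyl on a nitrogen on an aromatic ring. Within the data shown here, the only measured guide is a step that the two limits leave unreadable from compound 1 to compound 2, which also concerns the group on that nitrogen. With no readable size in that step, nothing measured points to a change, so no step beyond the usual scatter is expected in this assay, and the assay may well report only a limit again. The estimated change is a number no higher from compound 2 to compound 3 (the limit leaves the size open). For compound 3 the expected value is 20000 nM, with an estimated range of 8000 nM to 50000 nM.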

Compound 3, half-maximal cytotoxic concentration: > 20000 nM
Compound 3 gave a limit, no number; the forecaster's own chance of this, stated with the estimate: 75%; the middle value sits exactly at the limit.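

No step can be read between compound 1, compound 2 and compound 3, because each gives a limit of the assay and not a number in this assay: the limit of > 20000 nM in this assay, at which 3 of the 3 values shown sit.

The compounds shown leave open whether isopropyl, cyclopropyl and cyclopentyl on the nitrogen differ in cytotoxicity at all; none of the three has an exact value.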